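The compounds below may be only part of what the source reports. "The series", "measured", "known", "first", "only" and "open" are said of these compounds alone.

Measured so far, in a physicochemical assay for lipophilicity, read by HPLC, at pH 7.5; a higher number here means a more lipophilic compound, a lower number a more polar compound:

- compound 1 `CC[C@@H](Nc1c(C#N)c(-c2ccc(-c3ccncc3C)cc2)nc2cnccc12)C(N)=O` gives 2
- compound 2 `CC[C@@H](Nc1c(C#N)c(-c2ccc(Br)cc2)nc2cnccc12)C(=O)O` gives 1.6
- compound 3 `CCOc1ccccc1-c1ccc(-c2nc3cnccc3c(N[C@H](CC)C(=O)N(C)C)c2C#N)cc1` gives 3.7

Compound 1 holds the second highest of these three numbers. Its nearest neighbour is compound 2, whose value in this assay is lower by a gap that lies beyond the usual scatter of such measurements. The furthest is compound 3, whose value is higher by a wide gap, also beyond the scatter. All three share the same core, and differ only in the groups attached to it.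

Compound 4 `CC[C@@H](Nc1c(C#N)c(-c2ccc(-c3ccc(Cl)cc3)cc2)nc2cnccc12)C(N)=O` has not yet been measured. It differs from compound 1 in one place: 4-chlorophenyl in place of 3-methylpyridin-4-yl on an aromatic carbon. The group that leaves carries one hydrogen-bond acceptor in its six-membered aromatic ring with one hetero atom; the group that enters is a six-membered aromatic ring of carbon only with a chlorine, and carries no hydrogen-bond acceptor.

With no measured pair showing exactly this swap, the expectation rests on the numbers shown. Compound 3, which carries an ethoxy-substituted phenyl where compound 1 carries 3-methylpyridin-4-yl, gives the highest value of the three. On that basis the step from compound 1 to compound 4 is expected to be an increase of about a number 1.20 log units higher from compound 1 to compound 4 (beyond the scatter), clearly beyond the scatter. Compound 4 is therefore estimated at 3.2, within a range from 2.6 to 3.8.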

Compound 4, distribution coefficient: 3.1
Compound 4: the middle estimate sits 0.10 log units above what was measured, and the stated range covers the measured number.
By their numbers in this assay, from the lowest: compound 2; then compound 1; then compound 4; then compound 3.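

In this assay, 4-chlorophenyl in place of 3-methylpyridin-4-yl, on an aromatic carbon para to a large group, gives a number 1.10 log units higher from compound 1 to compound 4 (beyond the scatter), a large step. For the compounds shown here, this is the first reading of a change at this position alone, as compounds 2 and 3 each differ from compound 1 in more than one place. The two groups match in heavy-atom count, and neither has a hydrogen-bond donor or a net charge, yet the entering group has no hydrogen-bond acceptor and the leaving group has one; no measurement shown here explains the size of the step.

The swap changes several things at once, removing the ring nitrogen and the methyl and adding the chlorine, so the step cannot be divided among them. Plain phenyl, 3-methylphenyl and 4-methylphenyl at this position would separate those parts, while an aminomethyl or a carboxylic acid on the outer ring would show how far the number moves with other substituents there.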